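The compounds below may be only part of what the source reports. "The series", "measured", "known", "first", "only" and "open" are said of these compounds alone.

Measured compounds in the series:

compound 1, `O=[N+]([O-])c1ccc(CN2CCC(n3cc(CC(OCc4cc(-c5ccc(F)cc5)no4)c4ccc(Br)cc4)nn3)CC2)cc1` — 3000 nM
compound 2, `COc1ccc(-c2cc(COC(Cc3cn(C4CCN(Cc5ccc([N+](=O)[O-])cc5)CC4)nn3)c3ccc(Br)cc3)on2)cc1` — 3000 nM
compound 3, `O=[N+]([O-])c1ccc(CN2CCC(n3cc(CC(OCc4cc(-c5cccc(F)c5)no4)c4ccc(Br)cc4)nn3)CC2)cc1` — 5000 nM

All three values come from a functional assay on Caco-2 cells (Homo sapiens) for cytotoxicity, with a stated time of 48 h; a higher number here means a weaker inhibitor, a lower number a stronger inhibitor. The three numbers lie close to one another. Compound 2 differs from compound 1 by methoxy in place of fluoro on an aromatic carbon; the step in this assay is no change at the digits printed from compound 1 to compound 2 (within the scatter). Compound 3 differs from compound 1 in how its core is built: 3-fluorophenyl in place of 4-fluorophenyl on an aromatic carbon. The accompanying step is a 1.7-fold higher number from compound 1 to compound 3 (0.22 log units; within the scatter). Between compound 2 and compound 3 the step reads a 1.7-fold higher number from compound 2 to compound 3 (0.22 log units; within the scatter). None of the three steps leaves the scatter, so no order among compound 1, compound 2 and compound 3 can be drawn from these numbers.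

Compound 4, `COc1cccc(-c2cc(COC(Cc3cn(C4CCN(Cc5ccc([N+](=O)[O-])cc5)CC4)nn3)c3ccc(Br)cc3)on2)c1`, has not been measured in this assay. It differs from compound 3 by methoxy in place of fluoro on an aromatic carbon. Among the measured compounds shown here, this is the same kind of change as the one from compound 1 to compound 2, but the place is not identical: in the earlier pair the group sits para to a large group, here it sits meta to a large group. Since that earlier change gave no change at the digits printed from compound 1 to compound 2 (within the scatter), the expected step from compound 3 to compound 4 in this assay is a 1.1-fold lower number from compound 3 to compound 4 (0.05 log units; within the scatter), a step also expected to stay within the scatter. For the measured compounds named here, the difference in place adds some uncertainty, as no measured pair covers the meta arrangement with a methoxy.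

For compound 4 the estimated value in this assay is 4500 nM. The expected range for compound 4 runs from 2000 nM to 10000 nM.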

Compound 4, half-maximal inhibitory concentration: 5000 nM
The estimate for compound 4 lay 1.1-fold (0.05 log units) below the measured number; the range from low to high includes it.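

In this assay, the step from 3-fluorophenyl to 3-methoxyphenyl reads no change at the digits printed from compound 3 to compound 4 (within the scatter), and methoxy in place of fluoro on an aromatic carbon gives the same result on both cores: the same change on two cores in this assay, no change at the digits printed (within the scatter) from compound 1 to compound 2 and no change at the digits printed (within the scatter) from compound 3 to compound 4, 1.0-fold (0.00 log units) apart, within the scatter of two such steps

Among the compounds shown here, this shows that the change carried over between these two cores without a readable difference in this read-out, whether the group is the one in compound 2 or the one in compound 4. It does not show that the change would carry over to other cores or to other read-outs, and two steps of no visible size are a weak test of transfer, as a change that moves the number by a clear amount on one core has not been followed onto another. The other two new steps, a 1.7-fold higher number from compound 2 to compound 4 (0.22 log units; within the scatter) and a 1.7-fold higher number from compound 1 to compound 4 (0.22 log units; within the scatter), also stay within the scatter, so compound 4 takes no place in an order with the other three compounds.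

On these data alone, only fluoro and methoxy appear on this phenyl ring, so the effect of an amine, a carboxylic acid or a nitrile there remains open. Also open, as far as these compounds go, is what happens in this assay when the nitro group or the bromo substituent is replaced, as both stay fixed across all four compounds.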